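The source may hold more compounds than are shown below. What is called first, only, known or untested is meant among the compounds shown, and "the series" means these compounds.

Working notes on the series. In a functional assay on HepG2 cells (Homo sapiens) for cytotoxicity, read by MTT assay, with a stated time of 24 h (on this read-out lower numbers stand for stronger inhibition and higher numbers for weaker inhibition), compound 1 `O=C1/C(=C/c2cccc([N+](=O)[O-])c2)CN(S(=O)(=O)c2ccc(F)cc2)C/C1=C\c1cccc([N+](=O)[O-])c1` gives 8760 nM and compound 2 `COc1cc(/C=C2\CN(S(=O)(=O)c3ccc(F)cc3)C/C(=C\c3ccccc3F)C2=O)cc(OC)c1OC` gives 7940 nM. These two numbers lie within the scatter of each other, so compound 2 stands level with compound 1 and no order can be drawn between them.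

The next compound is compound 3 `COc1cc(/C=C2\CN(S(=O)(=O)c3ccc(F)cc3)C/C(=C\c3cccc([N+](=O)[O-])c3)C2=O)cc(OC)c1OC`, with this change from compound 2: 3-nitrophenyl in place of 2-fluorophenyl on a double-bonded chain carbon bound to a double-bonded ring carbon. That is, 3-nitrophenyl in place of 2-fluorophenyl on a double-bonded chain carbon bound to a double-bonded ring carbon. Among the measured compounds shown here, no two measured compounds differ in one place, so no measured step covers this change. Compound 1 also carries 3-nitrophenyl, and its 8760 nM sits within the scatter of compound 2.

The expected size in this assay is a 1.0-fold higher number from compound 2 to compound 3 (0.02 log units; within the scatter), with no direction beyond the scatter. For compound 3 the estimated value is 8300 nM, with an expected range of 3500 nM to 19000 nM.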

Compound 3, half-maximal inhibitory concentration: 3250 nM
Compound 3: the middle estimate sits 2.6-fold (0.41 log units) above what was measured, and the stated range ends above it.
By their numbers in this assay, from the lowest: compound 3; then compounds 2 and 1 (each within the scatter of the next).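

Exchanging 2-fluorophenyl for 3-nitrophenyl on a double-bonded chain carbon bound to a double-bonded ring carbon gives, in this assay, a 2.4-fold lower number from compound 2 to compound 3 (0.39 log units; beyond the scatter), a modest step beyond the scatter and a sign that the number responds to this change, which compounds 1 and 2, level with each other, could not show. Exchanging 3-nitrophenyl for 3,4,5-trimethoxyphenyl at that place gives a 2.7-fold lower number from compound 1 to compound 3 (0.43 log units; beyond the scatter), also modest and beyond the scatter, so compound 3, which carries both groups, stands lowest of the three. Nothing on hand accounts for either step.

Still open, going by these compounds, is whether 3-aminophenyl or 3-carboxyphenyl in place of 3-nitrophenyl would hold, extend or lose the lower number. On these data alone, each change also rests on a single pair of compounds, so its size on other partner groups remains unknown.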